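From methoxy to bromo on the shared core

The compounds below may be only part of what the source reports. "The series", "measured", "known", "first", "only" and "open" are said of these compounds alone.

In an ADME assay on Vero cells (Chlorocebus sabaeus) for cytotoxicity, read by resazurin assay, with a stated time of 72 h (on this read-out lower numbers stand for stronger inhibition and higher numbers for weaker inhibition), compound 1 (`Cc1ccc(C(=O)CCN2CCN(c3ccc(F)cc3)CC2)cc1`) gives 55400 nM and compound 2 (`COc1ccc(C(=O)CCN2CCN(c3ccc(F)cc3)CC2)cc1`) gives 55000 nM. These two numbers lie within the scatter of each other, so compound 2 stands level with compound 1. Compound 3 (`O=C(CCN1CCN(c2ccc(F)cc2)CC1)c1ccc(Br)cc1`) has yet to be measured. It differs from compound 2 in one place: bromo in place of methoxy on an aromatic carbon. This is bromo in place of methoxy on an aromatic carbon, para to a large group. Going by the values given here, only one measured step bears on it, methoxy in place of methyl on an aromatic carbon, a 1.0-fold lower number from compound 1 to compound 2 (0.00 log units; within the scatter), and that step stays within the scatter. Among the compounds with values here, no measured compound carries bromo, so this evidence is thin. No change beyond the scatter is therefore expected in this assay. The expected step is a 1.1-fold lower number from compound 2 to compound 3 (0.06 log units; within the scatter). For compound 3 the estimated value is 48000 nM, with an expected range from 22000 nM to 100000 nM.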

Compound 3, half-maximal inhibitory concentration: 99500 nM
For compound 3 the middle estimate is 2.1-fold (0.32 log units) below the measured one; low and high end bracket the measured number.
By their numbers in this assay, from the lowest: compounds 2, 1 and 3 (each within the scatter of the next).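

In this assay the place para to a large group now holds a third group, and bromo, a single heavy atom with no hydrogen-bond acceptor, does not take the number outside the scatter of either earlier compound. The change from methoxy gives a 1.8-fold higher number from compound 2 to compound 3 (0.26 log units; within the scatter) and the change from methyl gives a 1.8-fold higher number from compound 1 to compound 3 (0.25 log units; within the scatter), so this place has so far tolerated methyl, methoxy and bromo without a separation between the three compounds. Nothing measured here offers an explanation for these numbers.

As far as these compounds go, whether an amine, a carboxylic acid or a longer chain at this same place would give a step beyond the scatter remains open. From the compounds shown here alone, it is also open whether bromo would behave the same way at another place on this ring.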